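A few compounds are considered here, and "the series" means these few. Any claim that something is new, unique, unknown or untested is made for them only; others in the source may bear on it.

Measured so far:
compound 1 `COc1cc(-c2nnc(C3CCc4cc(F)ccc4O3)o2)cc(OC)c1OC` — 87000 nM
compound 2 `Fc1ccc2c(c1)CCC(c1nnc(-c3cn(Cc4c(F)cccc4F)nn3)o1)O2` — 88000 nM
compound 3 `Fc1ccc2c(c1)CCC(c1nnc(-c3cccc(Cl)c3)o1)O2` — 84800 nM

All three carry the same core and differ in the group attached to the five-membered ring; they were run in a functional assay; a higher number here means a weaker inhibitor, a lower number a stronger inhibitor. In this assay compound 1 gives 87000 nM, compound 2 gives 88000 nM and compound 3 gives 84800 nM. Among the compounds with values here, the three numbers sit within the scatter of one another, so no compound stands apart and no step between any two of them lies beyond the scatter. Compound 3 stands among them with its 3-chlorophenyl group; its number is indistinguishable from those of compound 1 and compound 2.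

Compound 4 `Fc1ccc2c(c1)CCC(c1nnc(-c3ccccc3)o1)O2` is not yet measured. It differs from compound 3 by hydrogen in place of chloro on an aromatic carbon — hydrogen in place of chloro on an aromatic carbon, meta to a large group; cut one bond further out, 3-chlorophenyl becomes phenyl.

Within the data shown here, no step between measured compounds is available to set a size for this change. Given that three different groups at this position all return numbers within the scatter, the expected step from compound 3 to compound 4 is a 1.1-fold higher number from compound 3 to compound 4 (0.03 log units; within the scatter), that is, none beyond the scatter in either direction. Compound 4 is accordingly expected to give about 90000 nM in this assay, with a range from 45000 nM to 180000 nM.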

Compound 4, half-maximal inhibitory concentration: 85900 nM
Compound 4: middle estimate off by 1.0-fold (0.02 log units), on the high side; the measured number falls inside the stated range.
By their numbers in this assay, from the lowest: compounds 3, 4, 1 and 2 (each within the scatter of the next).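

Hydrogen in place of chloro on an aromatic carbon, meta to a large group, is the only change shown that can be read in one place, and in this assay it gives a 1.0-fold higher number from compound 3 to compound 4 (0.01 log units; within the scatter). The chloro of the 3-chlorophenyl group is therefore not required for the number seen in this assay, since the plain phenyl of compound 4 stays within the scatter of compound 3, and the flat picture of the series now rests on a single-place comparison rather than only on groups that differ in several ways. Nothing shown here bears on why this change leaves the number where it stands.

Open, on these data alone, is whether a different group on this aromatic carbon, such as an amine, a carboxylic acid or a longer chain, would shift the number in this assay beyond the scatter, since chloro and hydrogen are the only two compared here. Also open, as far as these compounds go, is whether a change to the shared core, rather than to the group on the five-membered ring, would shift it.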